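Cytotoxicity of a Chloro Analogue in the Amidine Series

The compounds below may be only part of what the source reports. "The series", "measured", "known", "first", "only" and "open" are said of these compounds alone.

Three compounds of one shared core have been examined in an ADME assay on L6 cells (Rattus norvegicus) for cytotoxicity, read by resazurin assay; on this read-out higher numbers stand for weaker inhibition and lower numbers for stronger inhibition. Compound 1 `N=C(N)c1ccc(Nc2nc3cc(C(=N)N)ccc3[nH]2)cc1` gives 105000 nM in this assay. Compound 2 `N=C(N)c1ccc(Nc2nc3cc(C(F)(F)F)ccc3[nH]2)cc1` gives 41400 nM, the lowest of the three numbers, and compound 3 `CC(C)NC(=N)c1ccc(Nc2nc3cc(C(=N)NC(C)C)ccc3[nH]2)cc1` gives 108000 nM; the values of compound 1 and compound 3 lie within the scatter of each other. Within the data shown here, the only step between two compounds that differ in one place is a 2.5-fold lower number from compound 1 to compound 2 (0.40 log units; beyond the scatter).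

Compound 4 `N=C(N)c1ccc(Nc2nc3cc(Cl)ccc3[nH]2)cc1` differs from compound 2 by chloro in place of trifluoromethyl on an aromatic carbon. Among the measured compounds shown here, no measured step replaces trifluoromethyl by chloro, so the expectation rests on how little the numbers for this core have moved so far. The step from compound 2 to compound 4 in this assay is therefore expected to be small, at most a modest rise, as a 1.3-fold higher number from compound 2 to compound 4 (0.12 log units; within the scatter). For compound 4 in this assay the estimate is 55000 nM, within a range from 25000 nM to 110000 nM.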

Compound 4, half-maximal inhibitory concentration: 46400 nM
Compound 4: the middle estimate sits 1.2-fold (0.07 log units) above what was measured; the measured number falls inside the stated range.
By their numbers in this assay, from the lowest: compounds 2 and 4 (each within the scatter of the next); then compounds 1 and 3 (each within the scatter of the next).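

In this assay, chloro in place of trifluoromethyl on an aromatic carbon gives a 1.1-fold higher number from compound 2 to compound 4 (0.05 log units; within the scatter), so at this position the single chlorine atom and the group of four heavy atoms cannot be told apart. The step of a 2.3-fold lower number from compound 1 to compound 4 (0.35 log units; beyond the scatter) runs the same way as a 2.5-fold lower number from compound 1 to compound 2 (0.40 log units; beyond the scatter), which shows that two different groups in place of the amidine of compound 1 both go with a lower number, not trifluoromethyl alone. Nothing at hand accounts for this likeness between chloro and trifluoromethyl.

On these data alone, whether an amine, a carboxylic acid or a longer chain on this aromatic carbon would fall with compound 2 and compound 4 or with compound 1 remains open. Also open, as far as these compounds go, is whether chloro would give a similar step on the core of compound 3, with its isopropyl-substituted amidine groups.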